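This account rests on a few compounds, and the source may have more. Where it says the series, first, only, none or still open, it means among the compounds named here.

Working notes on the series in a physicochemical assay for solubility, read by mass spectrometry, in phosphate buffer, with a stated time of 24 h, at pH 7.4; on this read-out higher numbers stand for higher solubility and lower numbers for lower solubility.

Compound 3 `O=C(Nc1ccc(C(F)(F)F)cc1)NC1CCN(C(=O)C2CCOC2)CC1` gives 9.6 ug/mL and stands second highest of the three measured numbers. Its nearest neighbour is compound 1 `Cc1occc1C(=O)N1CCC(NC(=O)Nc2ccc(OC(F)(F)F)cc2)CC1`, which gives 8.6 ug/mL; the two values lie within the scatter and are not ordered here. The furthest is compound 2 `O=C(Nc1ccc(OC(F)(F)F)cc1)NC1CCN(C(=O)[C@@H]2CCOC2)CC1`, which gives 23 ug/mL, a gap beyond the scatter. Among the compounds with values here, the single measured step, a 2.7-fold higher number from compound 1 to compound 2 (0.43 log units; beyond the scatter), concerns the carbonyl substituent, not the aromatic ring.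

Compound 4 `O=C(Nc1ccc(OC(F)(F)F)cc1)NC1CCN(C(=O)C2CCOC2)CC1` is not yet measured. It differs from compound 3 by trifluoromethoxy in place of trifluoromethyl on an aromatic carbon. Within the data shown here, no measured step carries this change, so nothing among the measured pairs speaks directly to its size or direction. Compound 4 carries the same oxolan-3-yl carbonyl as compound 2, whose value is the highest of the three. On that basis compound 4 is expected to land between the values of compound 3 and compound 2, with a 1.8-fold higher number from compound 3 to compound 4 (0.25 log units; within the scatter) as the estimated step. The estimate for compound 4 is 17 ug/mL, within a range from 7 ug/mL to 40 ug/mL.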

Compound 4, solubility: 29 ug/mL
Compound 4: middle estimate off by 1.7-fold (0.23 log units), on the low side, within the range that was stated.
By their numbers in this assay, from the lowest: compounds 1 and 3 (each within the scatter of the next); then compounds 2 and 4 (each within the scatter of the next).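

In this assay the aromatic position now has its first measured step, a 3.0-fold higher number from compound 3 to compound 4 (0.48 log units; beyond the scatter), showing that trifluoromethoxy in place of trifluoromethyl on this carbon, para to a large group, moves the number beyond the scatter while the oxolan-3-yl carbonyl stays constant. The earlier carbonyl change recurs in the same direction, with oxolan-3-yl in place of 2-methylfuran-3-yl giving a 3.4-fold higher number from compound 1 to compound 4 (0.53 log units; beyond the scatter). The drawn stereocentre separates no values, with a 1.3-fold higher number from compound 2 to compound 4 (0.10 log units; within the scatter), and this pair cannot isolate the effect of a single configuration: the fact that one of compounds 2 and 4 is drawn with a defined configuration and the other without, at the place where they differ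

Still open, from the compounds shown here alone, is whether the step from trifluoromethyl to trifluoromethoxy holds with 2-methylfuran-3-yl on the carbonyl. Going by these compounds, it is also open where a nitrile or a methoxy group on the same aromatic carbon would fall.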